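A Pyrazole Replaces Methoxyphenyl in an Acid Amidase Inhibitor

The compounds below may be only part of what the source reports. "The series", "measured", "known", "first", "only" and "open" are said of these compounds alone.

Of the compounds shown here, three have been measured in an assay on isolated protein for inhibition of N-acylethanolamine-hydrolyzing acid amidase (Homo sapiens), read by fluorescence, with a stated time of 90 min; a higher number here means a weaker inhibitor, a lower number a stronger inhibitor. Compound 1 `COc1ccc(-c2ccc(COC3CN(C#N)C3)cc2)cc1` gives 0.94 nM, compound 2 `N#Cc1ccc(-c2cc(Oc3ccccc3)ccc2COC2CN(C#N)C2)cc1` gives 2.5 nM, and compound 3 `COc1cccc(-c2ccc(C(OC3CN(C#N)C3)c3ccccc3)cc2)c1` gives 11.6 nM. Compound 3 thus stands at the highest number of the three, and is the weakest inhibitor among them: its nearest neighbour is compound 2, its furthest is compound 1, and both gaps lie beyond the scatter of repeated measurements.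

Compound 4 `Cn1nccc1-c1ccc(C(OC2CN(C#N)C2)c2ccccc2)cc1` differs from compound 3 in a single place: 1-methyl-1H-pyrazol-5-yl in place of 3-methoxyphenyl on an aromatic carbon. For the measured compounds named here, no pair of measured compounds shows a change of this kind, so neither the direction nor the size of such a step can be read from the measured numbers; the shared core of compound 3 is kept, and only the aromatic group at that place changes. Without a measured precedent, a modest step is expected, more likely toward a higher number than a lower one, and the estimated step from compound 3 to compound 4 is a 1.7-fold higher number from compound 3 to compound 4 (0.24 log units; within the scatter). Compound 4 is therefore expected to give about 20 nM in this assay, with a likely range from 5 nM to 80 nM.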

Compound 4, half-maximal inhibitory concentration: 74.7 nM
Estimate against measurement, compound 4: 3.7-fold (0.57 log units) below; the range from low to high includes it.
By their numbers in this assay, from the lowest: compound 1; then compound 2; then compound 3; then compound 4.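

In this assay, 1-methyl-1H-pyrazol-5-yl in place of 3-methoxyphenyl gives a 6.4-fold higher number from compound 3 to compound 4 (0.81 log units; beyond the scatter) and so shows that the number responds to the group on this aromatic carbon, para to a large group. The earlier compounds shown here held no pair differing in one place, so they could not show this; here a step beyond the scatter shows that this position does not take the exchange without loss. The change replaces a six-membered aromatic ring of carbon only with a five-membered aromatic ring with 2 hetero atoms, and the methoxy group leaves with it, but no measurement on hand says which of these differences accounts for the step.

The compounds shown leave open whether the loss follows the ring itself or the absence of the methoxy group, a question that an unsubstituted phenyl, a pyridin-3-yl or a 1-methyl-1H-pyrazol-4-yl on the same carbon would help to settle. They also leave open whether the same exchange would cost as much on the core of compound 1 , which carries a methoxyphenyl group but no second phenyl ring on the carbon bearing the ether oxygen.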